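The compounds below may be only part of what the source reports. "The series", "measured", "known", "first", "only" and "open" are said of these compounds alone.

Measured compounds:
Compound 1 `CSc1nc(-c2ccc(F)cc2)c(-c2ccnc(NC3CCOCC3)c2)[nH]1` — "not determined" (no result reported) in a functional assay on blood (Homo sapiens) for inhibition; on this read-out lower numbers stand for stronger inhibition and higher numbers for weaker inhibition.
Compound 2 `C[S+]([O-])c1ccc(CSc2nc(-c3ccc(F)cc3)c(-c3ccncc3)[nH]2)cc1` — 380 nM in this assay.

Compound 1 therefore stands nowhere on the numbers: it carries no single value, and only compound 2 gives a fixed point. Compound 3 `CSc1nc(-c2ccc(F)cc2)c(-c2ccnc(NC(C)CCc3ccccc3)c2)[nH]1` differs from compound 1 in one place: 1-methyl-3-phenylpropyl in place of oxan-4-yl on a nitrogen on an aromatic ring. Going by the values given here, with no measured pair of this kind, the expected step in this assay is small, without a clear direction, and likely within the scatter. Compound 3 is estimated at 300 nM, with a range from 60 nM to 1500 nM.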

Compound 3, half-maximal inhibitory concentration: 2370 nM
Estimate against measurement, compound 3: 7.9-fold (0.90 log units) below, outside the stated range (above it).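

Going by these compounds alone, compound 1 has no single number in this assay, so no step to compound 3 can be read. What replacing oxan-4-yl with 1-methyl-3-phenylpropyl does to inhibition stays open, and nothing shown offers an explanation for the value of compound 3.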